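Cutting the Hydroxycarbamoyl Chain Back Once More

The source may report more compounds than this note shows. Statements on the series, on what has been measured and on what is new or still open speak of the compounds shown alone.

Compound 1 (`Nc1ncnc2c1c(-c1cnc3[nH]ccc3c1)nn2CCCCCCCCC(=O)NO`) and compound 2 (`Nc1ncnc2c1c(-c1cnc3[nH]ccc3c1)nn2CCCCCC(=O)NO`) share one core and differ in the chain that ends in hydroxycarbamoyl. In a functional assay on HCT-116 cells (Homo sapiens) for inhibition, read by MTT assay, with a stated time of 72 h (on this read-out lower numbers stand for stronger inhibition and higher numbers for weaker inhibition), compound 1 gives 5460 nM. Compound 2 gives 63700 nM, the higher of the two numbers and so the weaker inhibition. Compound 3 (`Nc1ncnc2c1c(-c1cnc3[nH]ccc3c1)nn2CCC(=O)NO`) has not yet been measured and carries the chain cut back further: hydroxycarbamoyl in place of 3-(hydroxycarbamoyl)propyl on a saturated chain carbon, two bonds along the chain from an aromatic nitrogen. The exchange sits on a saturated chain carbon, two bonds along the chain from an aromatic nitrogen.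

Among the compounds with values here, only one measured step bears on this change. It is the same exchange of groups made five bonds along the chain from an aromatic nitrogen, and it shows a 12-fold higher number from compound 1 to compound 2 (1.07 log units; beyond the scatter), a large step beyond the scatter. A single step does not establish a trend, and nothing measured yet shows how the change behaves at the new place. A further rise in this assay is still expected, though probably a smaller one. The expected step is a 2.4-fold higher number from compound 2 to compound 3 (0.37 log units; beyond the scatter). For compound 3 the estimated value is 150000 nM, with an expected range of 50000 nM to 450000 nM.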

Compound 3, half-maximal inhibitory concentration: > 150000 nM
Compound 3 gave a limit, no number; the forecaster's own chance of this, stated with the estimate: 35%; the middle value sits exactly at the limit.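

The reading for compound 3 in this assay is a limit of the assay and not a number: the limit of > 150000 nM in this assay, at which 1 of the 3 values shown sits. With hydroxycarbamoyl on a saturated chain carbon, two bonds along the chain from an aromatic nitrogen, the result is an at least 2.3-fold higher number from compound 2 to compound 3 (0.37 log units; beyond the scatter), so the rise seen with the earlier cut continues at this new place, and the limit leaves its full size unknown. Taken over the whole shortening, the result is an at least 27-fold higher number from compound 1 to compound 3 (1.43 log units; beyond the scatter), and all three compounds now fall in one order, with the number rising as the chain gets shorter and no compound going against it; this is the first time the order rests on more than a single step.

From the compounds shown here alone, whether a longer chain than that of compound 1 would bring the number down further remains open, and the three compounds give no indication of where such a trend would end. Also open, going by these compounds, is what a carboxylic acid or an amine at the end of the chain, in place of hydroxycarbamoyl, would do to the number at any of these chain lengths.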